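The compounds below may be only part of what the source reports. "The series", "measured", "known", "first", "only" and "open" are said of these compounds alone.

The measured compounds: compound 1 `O=CN1N=C(c2ccc(F)cc2)CC1c1cn(-c2ccccc2)nc1-c1ccc(Cl)c(Cl)c1` with 60.9%; compound 2 `CC(=O)N1N=C(c2ccc(C)cc2)CC1c1cn(-c2ccccc2)nc1-c1ccc(Cl)c(Cl)c1` with 70.3%; compound 3 `Fc1ccc(C2=NN(c3ccccc3)C(c3cn(-c4ccccc4)nc3-c3ccc(Cl)c(Cl)c3)C2)cc1` with 60.2%.

In a functional assay on the whole organism (strain Wistar) for inhibition, with Rattus norvegicus as the target, read by paw edema, with stated times of 30 min and 120 min, at a dose of 50 mg/kg by the oral route (on this read-out higher numbers stand for more inhibition at the one dose given (going by the name of the read-out) and lower numbers for less inhibition), compound 1 gives 60.9%, the second highest of the three numbers. Among the measured compounds shown here, its nearest neighbour is compound 3, and the one step measured, a number 0.7 percentage points lower from compound 1 to compound 3 (within the scatter), lies within the scatter. Compound 2 gives 70.3%, which the two values show to be within the scatter of compound 1 as well.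

Compound 4 `O=CN1N=C(c2ccc(Cl)cc2)CC1c1cn(-c2ccccc2)nc1-c1ccc(Cl)c(Cl)c1` differs from compound 1 in one place: chloro in place of fluoro on an aromatic carbon. For the measured compounds named here, no measured step touches this position; the only step known, a number 0.7 percentage points lower from compound 1 to compound 3 (within the scatter), sits elsewhere and is itself within the scatter. A step of no size beyond the scatter is therefore expected, a number 1.1 percentage points higher from compound 1 to compound 4 (within the scatter). Compound 4 is estimated at 62%, between 50% and 74%.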

Compound 4, a percentage reported as inhibition, in the whole organism at one dose (the size of the read-out at that dose, not a potency): 57.8%
Beside the measured number, compound 4's estimate is 4.2 percentage points above it, within the range that was stated.
By their numbers in this assay, from the lowest: compounds 4, 3, 1 and 2 (each within the scatter of the next, the first and the last beyond it).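

In this assay, among the compounds shown here, 4-fluorophenyl to 4-chlorophenyl gives a number 3.1 percentage points lower from compound 1 to compound 4 (within the scatter) and so supplies the first measured step at this position. On an aromatic carbon para to a large group, chloro and fluoro are not told apart by this read-out at the one dose given. Nothing measured bears on this result.

On these data alone, whether a methoxy group or an amine at this position would move the number beyond the scatter stays open. The compounds shown also leave open whether a hydroxyl group there would do so.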